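Z to E at the double bond of compound 2

This account rests on a few compounds, and the source may have more. Where it says the series, first, only, none or still open, it means among the compounds named here.

- Compound 1 (`COc1cc(/C=C/c2ccc(O[Si](C)(C)C(C)(C)C)cc2)cc(OC)c1`) gives > 200000 nM, a limit and not a number
- Compound 2 (`COc1ccc(/C=C\c2cc(O)cc(O)c2)cc1N`) gives 68000 nM

For the measured compounds named here, in a functional assay on HL-60 cells (Homo sapiens) (a lower number here means that less compound is needed, a higher number that more compound is needed for the effect), compound 2 gives 68000 nM, the only true number so far. Going by the values given here, the other reading stands at a limit, so no measured step exists to gauge a change.

Compound 3 (`COc1ccc(/C=C/c2cc(O)cc(O)c2)cc1N`) has yet to be measured. It relates to compound 2 as follows: the two compounds have the same atoms and bonds and differ only in configuration as drawn: 1 of 1 stereo elements differ; a double bond is drawn Z in compound 2 and E in compound 3. The double bond is drawn Z in compound 2 and E in compound 3, and nothing else changes.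

Among the compounds with values here, with no measured step to go on, no direction is favoured, and the expected step of a 1.1-fold lower number from compound 2 to compound 3 (0.05 log units; within the scatter) stays within the scatter. A limit reading remains possible. For compound 3 the estimated value is 60000 nM, with an expected range from 15000 nM to 200000 nM.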

Compound 3, concentration for half-maximal activity: > 200000 nM
Compound 3: only a limit was reported; the forecaster's own chance of this, stated with the estimate: 20%; at least 3.3-fold (0.52 log units) between middle value and limit.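

In this assay, for the compounds shown here, the double bond gives the first readable step, with the change from Z to E giving an at least 2.9-fold higher number from compound 2 to compound 3 (0.46 log units; beyond the scatter). The reading of compound 3, > 200000 nM, is a limit and not a number. The step can be assigned to the double bond alone because nothing else separates the pair: the fact that compounds 2 and 3 differ only in the configuration as drawn

As far as these compounds go, the real value of compound 3 stays open, so the full size of the step is unknown. Also open, from the compounds shown here alone, is whether the Z form keeps its advantage when other groups of compound 2 change, for instance with a carboxylic acid in place of the amine, since this pair tests the double bond with a single set of groups.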